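Methoxycyclohexyl in place of hydroxycyclobutylmethyl: stability expectation

A few compounds are considered here, and "the series" means these few. Any claim that something is new, unique, unknown or untested is made for them only; others in the source may bear on it.

Measured compounds:
compound 1, `N#Cc1cnc(NCc2cnccc2C(F)(F)F)cc1NC[C@H]1C[C@H](O)C1`: 61%
compound 2, `N#Cc1cnc(NCc2ccccc2C(F)(F)F)cc1N[C@H]1CC[C@@H](O)CC1`: 31%

Going by the values given here, in an ADME assay on S9 fraction from liver (Rattus norvegicus) for metabolic stability, with a stated time of 1 h (a higher number here means that more of the compound is left, a lower number that less of the compound is left), compound 1 gives 61%, the higher of the two numbers known so far. In this assay compound 2 gives 31%, a gap beyond the usual scatter of such measurements. Compound 3, `CO[C@H]1CC[C@@H](Nc2cc(NCc3cnccc3C(F)(F)F)ncc2C#N)CC1`, has not yet been measured in this assay. It differs from compound 1 in one place: 4-methoxycyclohexyl in place of (3-hydroxycyclobutyl)methyl on a nitrogen on an aromatic ring. Among the compounds with values here, no step between two measured compounds matches this change, so the expectation rests on the two known values and the change itself. Because compound 2 gives 31%, a downward step of a number 26 percentage points lower from compound 1 to compound 3 (beyond the scatter) is expected, beyond the scatter. Compound 3 is accordingly estimated at 35% in this assay, with a range from 15% to 58%.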

Compound 3, percent of the compound remaining: 1%
The estimate for compound 3 lay 34 percentage points above the measured number; the whole stated range lies above it.
By their numbers in this assay, from the lowest: compound 3; then compound 2; then compound 1.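

In this assay, putting 4-methoxycyclohexyl in place of (3-hydroxycyclobutyl)methyl on a nitrogen on an aromatic ring gives a number 60 percentage points lower from compound 1 to compound 3 (beyond the scatter), which shows that, on the core of compound 1, the outcome depends strongly on the group at this position. The change is composite: a four-membered ring gives way to a six-membered one, the hydrogen-bond donor is lost, and the group grows from 6 to 8 heavy atoms, and this single step cannot separate these differences. Nothing available here bears on why so little of compound 3 remains.

The compounds shown leave open whether (3-methoxycyclobutyl)methyl on the same core would follow compound 1 or compound 3, which would separate the methyl ether from the ring. On these data alone, how 4-aminocyclohexyl, an amine, would behave at this position also remains open.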